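Trifluoromethoxy to methyl: working notes on the series

The source may hold more compounds than are shown below. What is called first, only, known or untested is meant among the compounds shown, and "the series" means these compounds.

Measured in a functional assay on P388 cells (Mus musculus) for inhibition; on this read-out higher numbers stand for weaker inhibition and lower numbers for stronger inhibition:
- compound 1 `Oc1ccc(/C=C/c2ccc3ccccc3c2)cc1`: 4060 nM
- compound 2 `COc1ccc(/C=C/c2ccc3ccccc3c2)cc1`: > 5000 nM (a limit)
- compound 3 `FC(F)(F)Oc1ccc(/C=C/c2ccc3ccccc3c2)cc1`: > 5000 nM (a limit)

Compound 3 has no number, only the limit > 5000 nM in this assay. It shares the limit of > 5000 nM in this assay, at which 2 of the 3 values shown sit, with compound 2. The next compound, compound 4 `Cc1ccc(/C=C/c2ccc3ccccc3c2)cc1`, carries methyl in place of trifluoromethoxy on an aromatic carbon, para to a large group, as counted in methyl in place of trifluoromethoxy on an aromatic carbon here.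

The closest measured changes alter only what sits on the oxygen. These are an at least 1.2-fold higher number from compound 1 to compound 2 (0.09 log units; that floor lies within the scatter) and an at least 1.2-fold higher number from compound 1 to compound 3 (0.09 log units; that floor lies within the scatter), while a step that the two limits leave unreadable from compound 2 to compound 3 gives no size. None of them replaces the whole group on the aromatic carbon, so no measured size carries over directly. Compound 1 at 4060 nM is the only numerical anchor, and no step beyond the scatter is expected in this assay. The expected change is a step that the limit leaves unreadable from compound 3 to compound 4 in size. For compound 4 the estimate is 6000 nM, with an expected range from 2500 nM to 15000 nM, and another limit would not be a surprise.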

Compound 4, half-maximal inhibitory concentration: > 5000 nM
Compound 4: no number, only a limit (the forecaster's own chance of this, stated with the estimate: 55%); the middle value is on the limit's open side.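

In this assay compound 4 also gives only a limit, > 5000 nM, so replacing the whole group on this aromatic carbon with methyl, which carries no oxygen, yields no number either. Methyl in place of hydroxy gives an at least 1.2-fold higher number from compound 1 to compound 4 (0.09 log units; that floor lies within the scatter), so even this full replacement shows no change beyond the scatter, while the steps to compound 4 from compound 2 and from compound 3 cannot be read. The position now reads mostly as a ceiling for this assay, not as a scale of group effects: the limit of > 5000 nM in this assay, at which 3 of the 4 values shown sit.

As far as these compounds go, how far compound 2, compound 3 and compound 4 lie past the limit stays open, and so does their order. Also open, from the compounds shown here alone, is whether an amine or a carboxylic acid on this aromatic carbon would give a reading clearly lower than that of compound 1.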